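A Ring Amine One Bond Further Out

The source may hold more compounds than are shown below. What is called first, only, known or untested is meant among the compounds shown, and "the series" means these compounds.

Compound 3 `CC(C)NCC(Cc1ccc(Cl)c(F)c1)C(=O)N1CCN(c2ncnc3c2[C@H](C)SC3)CC1` is the strongest of the three measured compounds in an assay on isolated protein for inhibition of RAC-alpha serine/threonine-protein kinase (Homo sapiens) (on this read-out higher numbers stand for weaker inhibition and lower numbers for stronger inhibition), where compound 3 gives 2 nM; compound 2 `C[C@@H]1SCc2ncnc(N3CCN(C(=O)C(Cc4ccc(Cl)cc4)CN4CCCC4)CC3)c21` gives 3 nM and lies within the scatter of compound 3, while compound 1 `C[C@@H]1SCc2ncnc(N3CCN(C(=O)C(Cc4ccc(Cl)cc4)C4(N)CC4)CC3)c21` gives 42 nM, beyond the scatter from both. Compound 4 `C[C@@H]1SCc2ncnc(N3CCN(C(=O)C(Cc4ccc(Cl)c(F)c4)CC4(N)CC4)CC3)c21` is the next step from compound 3: 1-aminocyclopropyl in place of isopropylamino on a saturated chain carbon, two bonds along the chain from a carbonyl carbon. Among the measured compounds shown here, the only measured step with a related change is a 14-fold lower number from compound 1 to compound 2 (1.15 log units; beyond the scatter), a large gain, but there the 1-aminocyclopropyl sat directly on the chain carbon bound to the carbonyl carbon, whereas in compound 4 the same group enters one bond further out, so compound 4 keeps the spacing of compound 2 and compound 3 rather than that of compound 1. For the measured compounds named here, that step therefore does not transfer directly, and no measured pair isolates this exchange. A small shift, if any, toward a higher number is expected, within or near the scatter, as a 2.0-fold higher number from compound 3 to compound 4 (0.30 log units; within the scatter). Compound 4 is estimated at 4 nM, with a range from 1.5 nM to 15 nM.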

Compound 4, half-maximal inhibitory concentration: 3 nM
The estimate for compound 4 lay 1.3-fold (0.12 log units) above the measured number, and the stated range covers the measured number.
By their numbers in this assay, from the lowest: compounds 3, 2 and 4 (each within the scatter of the next); then compound 1.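

In this assay, 1-aminocyclopropyl in place of isopropylamino on a saturated chain carbon, two bonds along the chain from a carbonyl carbon, gives a 1.5-fold higher number from compound 3 to compound 4 (0.18 log units; within the scatter), so this place accepts the three-membered carbon ring without a change the assay can resolve. Before this result, 1-aminocyclopropyl was seen only in compound 1, on the chain carbon bound to the carbonyl carbon, where a 14-fold lower number from compound 1 to compound 2 (1.15 log units; beyond the scatter) showed a large step; one bond further out, the group stands within the scatter of isopropylamino. Nothing shown here bears on why this exchange leaves the number within the scatter.

The compounds shown leave open whether a morpholine ring or a dimethylamino group at this place would also stay within the scatter. They also leave open how a carboxylic acid there would read.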